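The source may hold more compounds than are shown below. What is called first, only, known or untested is meant among the compounds shown, and "the series" means these compounds.

Three compounds share one core and were compared in an assay on cells for activation of probable G-protein coupled receptor 34 (Mus musculus), with a stated time of 1 h; a higher number here means a larger maximal response, a lower number a smaller maximal response. Compound 1, `N[C@@H](COP(=O)(O)OCCCOC(=O)CCc1ccccc1OCc1cccc(OC2CCCCC2)c1)C(=O)O`, gives 0.11. Compound 2, `Cc1ccccc1Oc1cccc(COc2ccccc2CCC(=O)OCCCOP(=O)(O)OC[C@H](N)C(=O)O)c1`, gives 0.28, and compound 3, `Cc1cccc(Oc2cccc(COc3ccccc3CCC(=O)OCCCOP(=O)(O)OC[C@H](N)C(=O)O)c2)c1`, gives 0.29. Replacing the cyclohexyl on the aromatic oxygen by an aryl group raised the response: the step is a number 0.17 higher from compound 1 to compound 2 (beyond the scatter) and a number 0.18 higher from compound 1 to compound 3 (beyond the scatter). Moving the methyl on that aryl ring from one position to another changed almost nothing, the step being a number 0.010 higher from compound 2 to compound 3 (within the scatter). Compound 3 therefore holds the highest of the three numbers, with compound 2 within the scatter of it and compound 1 clearly lower.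

Compound 4, `N[C@@H](COP(=O)(O)OCCCOC(=O)CCc1ccccc1OCc1cccc(Oc2cccc(Cl)c2)c1)C(=O)O`, keeps the aryl ether of compound 3 and differs from it in one place: chloro in place of methyl on an aromatic carbon, so that 3-methylphenoxy becomes 3-chlorophenoxy. Among the compounds with values here, no measured pair swaps methyl for chloro, so the only guidance is indirect. The large gain came from the aryl ring itself, and the position of a small substituent on that ring made no difference beyond the scatter between compound 2 and compound 3. A single small substituent swap at the same spot is thus expected to give a step of a number 0.010 higher from compound 3 to compound 4 (within the scatter), that is, nothing beyond the scatter. Compound 4 is estimated at 0.3, likely between 0.18 and 0.42 in this assay .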

Compound 4, intrinsic activity: the largest response reached, as a fraction of the reference agonist's: 0.53
Compound 4: the middle estimate sits 0.23 below what was measured; the measured number lies above the stated range.
By their numbers in this assay, from the lowest: compound 1; then compounds 2 and 3 (each within the scatter of the next); then compound 4.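

In this assay, exchanging a single heavy atom on the aromatic ring, chloro in place of methyl, gives a step of a number 0.24 higher from compound 3 to compound 4 (beyond the scatter), so the substituent on this ring can shift the maximal response clearly, something the two methyl compounds gave no sign of. Set against the methyl isomer with the substituent placed differently, the 3-chlorophenyl group gives a number 0.25 higher from compound 2 to compound 4 (beyond the scatter), and set against the cyclohexyl group it gives a number 0.42 higher from compound 1 to compound 4 (beyond the scatter), which shows that an aryl ring carrying methyl reaches only part of the response available from this end of the molecule. Nothing given here explains why chloro and methyl, each a single heavy atom, differ so much at this place.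

As far as these compounds go, it remains open whether the gain is particular to chloro or would also appear with fluoro, bromo or trifluoromethyl at the same place. From the compounds shown here alone, it is equally open whether chloro elsewhere on that ring, or a second chloro on it, would keep, raise or lose the response seen for compound 4.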